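Swapping a hydroxycyclohexylmethyl side group for an oxane ring

The source may report more compounds than this note shows. Statements on the series, on what has been measured and on what is new or still open speak of the compounds shown alone.

Of the compounds shown here, two sharing one core have been measured in an assay on isolated protein for inhibition of protein kinase C theta type (Homo sapiens), read by TR-FRET, with a stated time of 2 h (a higher number here means a weaker inhibitor, a lower number a stronger inhibitor), so far. Compound 1 `N#Cc1cnc(NCc2cnccc2C(F)(F)F)cc1N[C@H]1C[C@H](O)C1` gives 900 nM in this assay. Going by the values given here, compound 2 `N#Cc1cnc(NCc2cnccc2C(F)(F)F)cc1NC[C@H]1CC[C@@H](O)CC1` gives 58 nM in this assay, the lowest of the two numbers; the only step known, a 16-fold lower number from compound 1 to compound 2 (1.19 log units; beyond the scatter), was large and lay beyond the scatter.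

Compound 3 `N#Cc1cnc(NCc2cnccc2C(F)(F)F)cc1NC1CCOCC1` has not yet been measured. It differs from compound 2 by oxan-4-yl in place of (4-hydroxycyclohexyl)methyl on a nitrogen on an aromatic ring. Among the compounds with values here, no measured step covers this exact change; the step from compound 1 to compound 2 shows only that the group on this nitrogen can shift the number a great deal. Since the entering group again sits directly on the nitrogen, as in compound 1, a move back toward compound 1 is expected, though not the whole way: compound 3 is expected to give 400 nM in this assay, within 100 nM to 1500 nM, meaning an expected step of a 6.9-fold higher number from compound 2 to compound 3 (0.84 log units; beyond the scatter).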

Compound 3, half-maximal inhibitory concentration: 900 nM
Compound 3: the middle estimate sits 2.3-fold (0.35 log units) below what was measured; the measured number falls inside the stated range.
By their numbers in this assay, from the lowest: compound 2; then compounds 1 and 3 (each within the scatter of the next).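

In this assay, the oxan-4-yl group gives up all of the gain seen with (4-hydroxycyclohexyl)methyl, with a 16-fold higher number from compound 2 to compound 3 (1.19 log units; beyond the scatter) on this nitrogen. Against 3-hydroxycyclobutyl, however, there is no change at the digits printed from compound 1 to compound 3 (within the scatter), so these two different groups cannot be told apart here and only compound 2 stands apart, which also shows that a hydroxyl on the ring, present in compound 1, does not alone give the low number of compound 2. Nothing measured on these compounds explains the result.

As far as these compounds go, the step from compound 2 to compound 3 changes the ring, the hydroxyl and the methyl link together, so it remains open which of them matters. An oxan-4-ylmethyl group, or a 4-hydroxycyclohexyl group without the methyl link, would help separate them.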